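This account rests on a few compounds, and the source may have more. Where it says the series, first, only, none or still open, it means among the compounds named here.

Working notes on the series.

Compound 1, `ClCc1ccc(Cn2cnc3c(Cl)ncnc32)cc1`, and compound 2, `Nc1nc(Cl)c2ncn(Cc3ccc(CCl)cc3)c2n1`, share a core; compound 3, `ClCc1ccccc1Cn1cnc2c(Cl)ncnc21`, has the same atoms joined differently, and the difference between the two cores is not broken down here. In a functional assay on CCRF-CEM cells (Homo sapiens) for cytotoxicity, read by sulforhodamine B assay, with a stated time of 48 h (a lower number here means that less compound is tolerated, a higher number that more compound is tolerated), compound 1 reports only a limit, > 100000 nM. In this assay compound 2 likewise reports only a limit, > 100000 nM. In this assay, among the measured compounds shown here, compound 3 gives 8120 nM, the only number so far. The change amino in place of hydrogen on an aromatic carbon gives a step that the two limits leave unreadable from compound 1 to compound 2, since (the limit of > 100000 nM in this assay, at which 2 of the 3 values shown sit).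

Compound 4, `Nc1nc(Cl)c2ncn(Cc3ccccc3CCl)c2n1`, awaits this assay. The change amino in place of hydrogen on an aromatic carbon is the same as that from compound 1 to compound 2. That earlier step is unreadable, so compound 4 is estimated near compound 3 on the basis of 8120 nM, with wide margins.

The expected step of a 1.5-fold higher number from compound 3 to compound 4 (0.17 log units; within the scatter) is an estimate only. Compound 4 is therefore expected at 12000 nM, estimated between 3000 nM and 60000 nM.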

Compound 4, concentration lethal to 50% of the cells: > 100000 nM
Compound 4: no number, only a limit; the forecaster's own chance of this, stated with the estimate: 15%; at least 8.3-fold (0.92 log units) between middle value and limit.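

In this assay, amino in place of hydrogen on an aromatic carbon gives an at least 12-fold higher number from compound 3 to compound 4 (1.09 log units; beyond the scatter). Compound 4 reports only a limit, > 100000 nM, so this size is a lower bound and not a measured step. The same change on the core of compound 1 cannot be read, so the compounds show neither that the step carries over between the two cores nor that it differs, since compound 2 and compound 4 both stop at a limit: the limit of > 100000 nM in this assay, at which 3 of the 4 values shown sit.

Left open is how a hydroxyl or a methylamino group on that same aromatic carbon, between two ring nitrogen atoms, would compare with amino on the core of compound 3. From the compounds shown here alone, a readable value for an amino compound on either core also remains open.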